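A few compounds are considered here, and "the series" means these few. Any claim that something is new, unique, unknown or untested is made for them only; others in the source may bear on it.

Compound 1 `COc1cccc(S(=O)(=O)c2n[nH]c3ccc(N4CCN(C)CC4)cc23)c1` gives 100% in a functional assay on HeLa cells for antagonist activity at 5-hydroxytryptamine receptor 6 (Homo sapiens); on this read-out lower numbers stand for smaller maximal responses and higher numbers for larger maximal responses.
Compound 2 `CN1CCN(c2ccc3[nH]nc(S(=O)(=O)c4c(Cl)cccc4Cl)c3c2)CC1` gives 100% in this assay.

Compound 2 stands level with compound 1 in this assay. Compound 3 `CN1CCN(c2ccc3[nH]nc(S(=O)(=O)c4ccc(F)cc4)c3c2)CC1` differs from compound 2 in one place: 4-fluorophenyl in place of 2,6-dichlorophenyl on a sulfonyl sulfur. Among the compounds with values here, the only measured step, no change at the digits printed from compound 1 to compound 2 (within the scatter), also exchanged the ring on the sulfonyl sulfur and left the largest response unchanged. A similar ring exchange is therefore expected to give no step beyond the scatter; the expected step is no change at the digits printed from compound 2 to compound 3 (within the scatter). For compound 3 the estimate in this assay is 100%, with a range from 85% to 110%.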

Compound 3, largest response reached (reported as Imax), in percent of the reference or control that the assay uses: 98%
Compound 3: middle estimate off by 2 percentage points, on the high side; the measured number falls inside the stated range.
By their numbers in this assay, from the lowest: compounds 3, 1 and 2 (each within the scatter of the next).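

In this assay, a third ring on the sulfonyl sulfur, 4-fluorophenyl, gives a number 2 percentage points lower from compound 2 to compound 3 (within the scatter) and a number 2 percentage points lower from compound 1 to compound 3 (within the scatter). The largest response therefore does not separate the 3-methoxyphenyl, 2,6-dichlorophenyl and 4-fluorophenyl compounds, so this position has now tolerated a third phenyl ring with a different substituent. Nothing measured here explains this lack of separation. Still open, as far as these compounds go, is whether a phenyl ring carrying an amine or a carboxylic acid, or a non-aromatic group such as cyclohexyl, on the sulfonyl sulfur would keep this response.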